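Plasma protein binding across three benzylic substituents, fourth pending

The source may report more compounds than this note shows. Statements on the series, on what has been measured and on what is new or still open speak of the compounds shown alone.

The three measured compounds share one core and differ only in the group on the six-membered aromatic ring of carbon only. In an ADME assay on a cell-free system (plasma, Homo sapiens) for protein binding, with Plasma (Rattus norvegicus) as the target, compound 1 `Cc1ccn(-c2ccc(Cn3cc(C(=O)O)c(=O)c4c(F)cccc43)cc2)n1` gives 92.3%; compound 2 `Cc1cn(-c2ccc(Cn3cc(C(=O)O)c(=O)c4c(F)cccc43)cc2)cn1` gives 89.8%, and compound 3 `O=C(O)c1cn(Cc2ccc(-n3ccc4cnccc43)cc2)c2cccc(F)c2c1=O` gives 98.2%. Compound 1 thus has the second highest of the three unbound fractions; its nearest is compound 2, with a 1.3-fold higher unbound fraction from compound 1 to compound 2 (0.12 log units; within the scatter), and its furthest is compound 3, with a 4.3-fold lower unbound fraction from compound 1 to compound 3 (0.63 log units; beyond the scatter). The same contrast appears as a 5.7-fold lower unbound fraction from compound 2 to compound 3 (0.75 log units; beyond the scatter).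

Compound 4 `O=C(O)c1cn(Cc2ccc(N3CCOC3=O)cc2)c2cccc(F)c2c1=O` is not yet measured. It differs from compound 1 as follows: 2-oxo-1,3-oxazolidin-3-yl in place of 3-methyl-1H-pyrazol-1-yl on an aromatic carbon. For the measured compounds named here, no measured step exchanges a five-membered aromatic ring for a five-membered non-aromatic ring, so none bears on it directly. The step to compound 2, swapping one five-membered aromatic ring with 2 hetero atoms for another, stayed within the scatter, and only the larger group of 9 heavy atoms moved the reading beyond it. The entering group matches the leaving group in heavy-atom count and acceptor count, so at most a small shift is expected, estimated as a 1.6-fold higher unbound fraction from compound 1 to compound 4 (0.19 log units; within the scatter). Compound 4 is therefore expected to give 88%, estimated within 80% to 94%.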

Compound 4, plasma protein binding: 77.6%
For compound 4 the middle estimate is 1.9-fold (0.27 log units) (unbound fraction) below the measured one, outside the stated range (below it).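

At this position on the six-membered aromatic ring of carbon only, equal printed counts of heavy atoms and acceptors did not keep the reading in place in this assay: 2-oxo-1,3-oxazolidin-3-yl gives a 2.9-fold higher unbound fraction from compound 1 to compound 4 (0.46 log units; beyond the scatter) in place of 3-methyl-1H-pyrazol-1-yl and a 2.2-fold higher unbound fraction from compound 2 to compound 4 (0.34 log units; beyond the scatter) in place of 4-methyl-1H-imidazol-1-yl even though the exchange between those two aromatic groups stayed within the scatter. Group size alone therefore does not set the reading here, and the series now spans a 12-fold higher unbound fraction from compound 3 to compound 4 (1.09 log units; beyond the scatter) with compound 4 holding the highest unbound fraction of the four, its steps to all three others lying beyond the scatter. Nothing available accounts for this shift.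

The change from 3-methyl-1H-pyrazol-1-yl to 2-oxo-1,3-oxazolidin-3-yl alters the ring's aromaticity, its atoms and its exocyclic carbonyl together, so the compounds shown do not separate these features. A pyrrolidin-2-one, with a ring carbon in place of the ring oxygen, or an open-chain amide at this position would bear on which feature goes with the step.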